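This account rests on a few compounds, and the source may have more. Where it says the series, first, only, none or still open, it means among the compounds named here.

Compound 1 `Fc1ccc(-c2noc3c2CCNCC3)cc1`: 1230 nM
Compound 2 `Cc1ccc(-c2n[nH]c3c2CCNCC3)cc1`: > 10000 nM

In an assay on cells for displacement of a labelled ligand from 5-hydroxytryptamine receptor 5A (Homo sapiens), read by scintillation counting, with a stated time of 1.5 h (on this read-out higher numbers stand for weaker inhibition and lower numbers for stronger inhibition), compound 1 gives 1230 nM. For compound 2 only a limit is known, > 10000 nM, which is the limit of > 10000 nM in this assay, at which 1 of the 2 values shown sits. Compound 3 `Fc1ccc(-c2n[nH]c3c2CCNCC3)cc1` carries the change (fluoro in place of methyl on an aromatic carbon), fluoro in place of methyl on an aromatic carbon, at the place para to a large group. Going by the values given here, no measured step covers this change, so the step is expected to be an at least 2.0-fold lower number from compound 2 to compound 3 (0.30 log units; that floor lies within the scatter), a move toward stronger inhibition with a wide uncertainty, since compound 2 is known only as a limit. Compound 3 is therefore estimated at 5000 nM in this assay, between 1200 nM and 20000 nM, with a real chance of another limit.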

Compound 3, inhibition constant: > 10000 nM
Compound 3: no number, only a limit (the forecaster's own chance of this, stated with the estimate: 40%); middle value at least 2.0-fold (0.30 log units) from the limit.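

Compound 2 and compound 3 are both only limits in this assay, so no step between them can be read: the limit of > 10000 nM in this assay, at which 2 of the 3 values shown sit.

As far as these compounds go, whether fluoro in place of methyl on an aromatic carbon changes inhibition in this assay remains open.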